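Anilide Variation on a Shared Core: Toward Compound 4

This account rests on a few compounds, and the source may have more. Where it says the series, first, only, none or still open, it means among the compounds named here.

Compound 1 `O=C(CN1CCN(c2nnc(Cc3ccncc3)c3ccccc23)CC1)Nc1ccc(F)c(F)c1`: 2320 nM
Compound 2 `Cc1ccccc1NC(=O)CN1CCN(c2nnc(Cc3ccncc3)c3ccccc23)CC1`: 15000 nM
Compound 3 `Cc1ccc(NC(=O)CN2CCN(c3nnc(Cc4ccncc4)c4ccccc34)CC2)c(C)c1`: 1930 nM

In a functional assay on HT-29 cells (Homo sapiens) for cytotoxicity, read by MTT assay, with a stated time of 72 h (on this read-out lower numbers stand for stronger inhibition and higher numbers for weaker inhibition), compound 3 stands at the low end of the three numbers; its gap to compound 1 is within the scatter, whereas a 7.8-fold lower number from compound 2 to compound 3 (0.89 log units; beyond the scatter). Compound 4 `Cc1ccc(F)cc1NC(=O)CN1CCN(c2nnc(Cc3ccncc3)c3ccccc23)CC1` differs from compound 3 in one place: 5-fluoro-2-methylphenyl in place of 2,4-dimethylphenyl on an amide-type nitrogen. For the measured compounds named here, two measured steps bear on this. a 1.2-fold lower number from compound 1 to compound 3 (0.08 log units; within the scatter), so exchanging methyls for fluorines on this ring did little. But a 7.8-fold lower number from compound 2 to compound 3 (0.89 log units; beyond the scatter), and compound 4 gives up that methyl while adding a fluorine elsewhere. A modest rise in the number is therefore expected, a 2.6-fold higher number from compound 3 to compound 4 (0.41 log units; beyond the scatter), though smaller than the full step back to compound 2. Compound 4 is estimated at 5000 nM, within a range from 1800 nM to 14000 nM.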

Compound 4, half-maximal inhibitory concentration: 470 nM
Compound 4: the middle estimate sits 11-fold (1.03 log units) above what was measured; the whole stated range lies above it.
By their numbers in this assay, from the lowest: compound 4; then compounds 3 and 1 (each within the scatter of the next); then compound 2.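

Adding a fluoro to the anilide ring gives a 32-fold lower number from compound 2 to compound 4 (1.50 log units; beyond the scatter) in this assay, so this single change on the ring carries a large effect. The 2,4-dimethylphenyl and 3,4-difluorophenyl rings had stood within the scatter of each other, yet 5-fluoro-2-methylphenyl separates from both, with a 4.1-fold lower number from compound 3 to compound 4 (0.61 log units; beyond the scatter) and a 4.9-fold lower number from compound 1 to compound 4 (0.69 log units; beyond the scatter) on the same amide-type nitrogen. Nothing at hand explains these steps.

On these data alone, whether a chloro, methoxy or nitrile group in place of this fluoro would give a similar step remains open. So does whether the fluoro would have the same effect on a ring without the methyl.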